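Azetidinyl Carbonyl in Place of the Aminobutyl Chain

The compounds below may be only part of what the source reports. "The series", "measured", "known", "first", "only" and "open" are said of these compounds alone.

Compound 1 `CC(=O)N1CCC(NS(=O)(=O)c2ccc(NC(=O)c3ccccc3C)c3ccccc23)CC1`: 6.7 nM
Compound 2 `COCC(=O)N1CCC(NS(=O)(=O)c2ccc(NC(=O)c3ccccc3C)c3ccccc23)CC1`: 15.8 nM
Compound 3 `Cc1ccccc1C(=O)Nc1ccc(S(=O)(=O)NC2CCN(C(=O)CCCCN)CC2)c2ccccc12`: 199 nM

In an assay on L1.2 cells for binding affinity to C-C chemokine receptor type 8 (Homo sapiens) (a lower number here means a stronger inhibitor, a higher number a weaker inhibitor), compound 3 gives the highest number of the three, set apart by a 30-fold higher number from compound 1 to compound 3 (1.47 log units; beyond the scatter) and by a 13-fold higher number from compound 2 to compound 3 (1.10 log units; beyond the scatter). Compound 4 `Cc1ccccc1C(=O)Nc1ccc(S(=O)(=O)NC2CCN(C(=O)N3CCC3)CC2)c2ccccc12` differs from compound 3 in one place: azetidin-1-yl in place of 4-aminobutyl on a carbonyl carbon. Both measured steps bear on this change, as they also alter the group on this carbonyl carbon; each move from a short group to the amine-bearing chain brought a large rise. Compound 4 drops that chain for a small ring, so a large fall back toward the numbers of compound 1 and compound 2 is expected, estimated as a 13-fold lower number from compound 3 to compound 4 (1.12 log units; beyond the scatter). Compound 4 is therefore estimated at 15 nM, with a range from 5 nM to 50 nM.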

Compound 4, inhibition constant: 3.5 nM
Compound 4: middle estimate off by 4.3-fold (0.63 log units), on the high side; measured number outside the range, below it.
By their numbers in this assay, from the lowest: compounds 4 and 1 (each within the scatter of the next); then compound 2; then compound 3.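

In this assay the azetidin-1-yl group on this carbonyl carbon recovers everything lost with the 4-aminobutyl chain, giving a 57-fold lower number from compound 3 to compound 4 (1.75 log units; beyond the scatter) and also a 4.5-fold lower number from compound 2 to compound 4 (0.65 log units; beyond the scatter) against methoxymethyl. Against methyl the change reads a 1.9-fold lower number from compound 1 to compound 4 (0.28 log units; within the scatter) and so leaves the two groups indistinguishable, which shows that this carbonyl carbon accepts a ring-bearing nitrogen as well as a small alkyl group. Nothing available explains these steps. The compounds shown leave open whether pyrrolidine, piperidine or dimethylamino would serve equally well here. They also leave open whether a pentyl chain, without the terminal amine, would bring the same rise as 4-aminobutyl.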